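The source may report more compounds than this note shows. Statements on the series, on what has been measured and on what is new or still open speak of the compounds shown alone.

Measured compounds in an assay on isolated protein for agonist activity at Bile acid receptor (Homo sapiens), read by FRET; on this read-out higher numbers stand for an effect only at larger amounts of compound and lower numbers for an effect already at smaller amounts:
compound 1, `CN(Cc1cccc(C(=O)O)c1)c1ccc(OCc2c(-c3c(Cl)cccc3Cl)noc2C2CC2)nc1C(F)(F)F`, gives 3 nM
compound 2, `CN(Cc1ccc(C(=O)O)cc1)c1ccc(OCc2c(-c3c(Cl)cccc3Cl)noc2C2CC2)nc1C(F)(F)F`, gives 12 nM

Going by the values given here, compound 2 stands at the highest of the two numbers so far; its only neighbour is compound 1, and the step of a 4.0-fold higher number from compound 1 to compound 2 (0.60 log units; beyond the scatter) separates the two, a move that lies beyond the scatter.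

Compound 3, `CCN(Cc1ccc(C(=O)O)cc1)c1ccc(OCc2c(-c3c(Cl)cccc3Cl)noc2C2CC2)nc1C(F)(F)F`, has not yet been measured. It differs from compound 2 by methyl in place of hydrogen on a saturated chain carbon bound to a nitrogen on an aromatic ring. Among the compounds with values here, the one measured step in hand, a 4.0-fold higher number from compound 1 to compound 2 (0.60 log units; beyond the scatter), concerns the position of the carboxylic acid on the benzylic ring and says nothing about the saturated chain carbon bound to the ring nitrogen. Within the data shown here, no step of the present kind has been measured, so there is no basis for a direction.

The expectation for compound 3 is therefore a step of no change at the digits printed from compound 2 to compound 3 (within the scatter) that stays within the scatter. Compound 3 is estimated in this assay at 12 nM, with a range from 4 nM to 40 nM.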

Compound 3, half-maximal effective concentration: 194 nM
Estimate against measurement, compound 3: 16-fold (1.21 log units) below, outside the stated range (above it).
By their numbers in this assay, from the lowest: compound 1; then compound 2; then compound 3.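

In this assay, the saturated chain carbon bound to a nitrogen on an aromatic ring proves far from tolerant: going from methyl to ethyl, with only 1 heavy atom added, gives a 16-fold higher number from compound 2 to compound 3 (1.21 log units; beyond the scatter). This step is larger than the one seen on moving the carboxylic acid around the benzylic ring, which gave a 4.0-fold higher number from compound 1 to compound 2 (0.60 log units; beyond the scatter), so within these compounds the chain on the nitrogen weighs more heavily on the read-out than the position of the acid. No measurement at hand gives a reason for the size of this step.

Still open, on these data alone, is whether a longer chain such as propyl, a branched isopropyl or a cyclopropyl at this place would push the number higher still, or whether a hydrogen on the nitrogen would bring it lower. Also open, as far as these compounds go, is whether ethyl costs as much alongside the 3-carboxyphenyl group of compound 1.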